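Taking the Bromo Group off Compound 2

The source may hold more compounds than are shown below. What is called first, only, known or untested is meant among the compounds shown, and "the series" means these compounds.

Among the compounds with values here, in a functional assay on CCRF-CEM cells (Homo sapiens) for antiproliferative activity, read by fluorescence and resazurin assay, with a stated time of 48 h (on this read-out higher numbers stand for weaker inhibition and lower numbers for stronger inhibition), only two compounds have numbers so far. Compound 1 `CCOc1ccc2nc(Cl)c(/C=N/NC(=O)c3cc4cc([N+](=O)[O-])ccc4oc3=O)cc2c1` gives 15700 nM and compound 2 `O=C(N/N=C/c1ccncc1)c1cc2cc(Br)ccc2oc1=O` gives 6340 nM as the lower of the two numbers, a gap beyond the usual scatter. These two compounds differ in more than one place, so their gap does not reveal what any single group contributes. Compound 3 `O=C(N/N=C/c1ccncc1)c1cc2ccccc2oc1=O` differs from compound 2 by one change (hydrogen in place of bromo on an aromatic carbon), hydrogen in place of bromo on an aromatic carbon. Within the data shown here, no measured pair shows this change on its own, so the expectation is uncertain: a modest step toward weaker inhibition in this assay seems likely, though it may not exceed the scatter. The expected 1.6-fold higher number from compound 2 to compound 3 (0.20 log units; within the scatter) is a small rise in the number. For compound 3 the estimate is 10000 nM (expected range 4000 nM to 30000 nM).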

Compound 3, half-maximal inhibitory concentration: 3110 nM
Compound 3: middle estimate off by 3.2-fold (0.51 log units), on the high side; measured number below the stated range.
By their numbers in this assay, from the lowest: compound 3; then compound 2; then compound 1.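

In this assay hydrogen in place of bromo on an aromatic carbon gives a 2.0-fold lower number from compound 2 to compound 3 (0.31 log units; beyond the scatter) and so moves toward stronger inhibition, a change beyond the usual scatter. Within the data shown here, this is the first pair here that isolates a single group, and it shows that the bromo group is not needed for activity: the compound without it does better. No measurement here accounts for why the number falls.

As far as these compounds go, it remains open whether another group on this aromatic carbon, such as fluoro, methoxy or an amine, would lower the number further or raise it. This single pair also cannot say whether removing a group from this position would have the same effect when the rest of the molecule differs, as it does in compound 1.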